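Aryl swap on the ring nitrogen: compound 2 to compound 3

The source may hold more compounds than are shown below. What is called first, only, known or untested is meant among the compounds shown, and "the series" means these compounds.

Compound 1 `N#CC1=C(N)Oc2c(N)cc3nc4ccccc4nc3c2C12C(=O)N(Cc1cnnn1-c1ccccc1Br)c1ccccc12` gives 38000 nM in a functional assay on HepG2 cells (Homo sapiens) for antiproliferative activity, read by MTT assay, with a stated time of 48 h; on this read-out higher numbers stand for weaker inhibition and lower numbers for stronger inhibition. Compound 2 `COc1ccccc1-n1nncc1CN1C(=O)C2(C(C#N)=C(N)Oc3c(N)cc4nc5ccccc5nc4c32)c2ccccc21` in this assay is reported only as a limit, > 50000 nM, which is the limit of > 50000 nM in this assay, at which 1 of the 2 values shown sits. The single measured step, an at least 1.3-fold higher number from compound 1 to compound 2 (0.11 log units; that floor lies within the scatter), has a floor that lies within the scatter, so compound 2 stands at or beyond the weak end of the two numbers shown. Compound 3 `CCc1cccc(CC)c1-n1nncc1CN1C(=O)C2(C(C#N)=C(N)Oc3c(N)cc4nc5ccccc5nc4c32)c2ccccc21` differs from compound 2 by 2,6-diethylphenyl in place of 2-methoxyphenyl on an aromatic nitrogen. Going by the values given here, no measured step covers a change of this kind, so nothing beyond the scatter is expected in this assay. Compound 3 is therefore estimated at 60000 nM, with a range from 25000 nM to 150000 nM, and is expected most likely to return again as a limit. The expected step that the limit leaves unreadable from compound 2 to compound 3 is thus essentially flat.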

Compound 3, half-maximal inhibitory concentration: 16500 nM
The estimate for compound 3 lay 3.6-fold (0.56 log units) above the measured number; measured number outside the range, below it.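

In this assay, the aryl group on this aromatic nitrogen can move the number beyond the scatter, which the earlier pair did not show: 2,6-diethylphenyl gives a 2.3-fold lower number from compound 1 to compound 3 (0.36 log units; beyond the scatter) and an at least 3.0-fold lower number from compound 2 to compound 3 (0.48 log units; beyond the scatter). The second of these steps is only a floor, as compound 2 is reported as a limit: the limit of > 50000 nM in this assay, at which 1 of the 3 values shown sits.

Still open, from the compounds shown here alone, is whether the lower number follows the two ethyl groups or simply the absence of bromo and methoxy. A plain phenyl or a 2-ethylphenyl on this nitrogen would separate these readings.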